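Sulfonyl substituent exchange in the bromophenyl enone series

The source may report more compounds than this note shows. Statements on the series, on what has been measured and on what is new or still open speak of the compounds shown alone.

Measured compounds:
Compound 1, `O=C(/C(=C\c1ccc(O)cc1)S(=O)(=O)Cc1ccc(F)cc1)c1ccc(Br)cc1`, 10000 nM
Compound 2, `Cc1ccc(C)c(/C=C(\C(=O)c2ccc(Br)cc2)S(=O)(=O)Cc2ccc(F)cc2)c1`, 1000 nM
Compound 3, `O=C(/C(=C\c1ccc(Br)cc1)S(=O)(=O)c1ccccc1Br)c1ccc(Br)cc1`, 1000 nM

In a functional assay on DU-145 cells (Homo sapiens) for inhibition, read by trypan blue exclusion, with a stated time of 96 h (a lower number here means a stronger inhibitor of growth, a higher number a weaker inhibitor of growth), compound 3 gives 1000 nM, level with compound 2 at the digits recorded; compound 1 stands clearly higher than both. Among the compounds with values here, the one step so far, a 10-fold lower number from compound 1 to compound 2 (1.00 log units; beyond the scatter), changes the aryl group on the double-bonded chain carbon and leaves the sulfonyl side untouched.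

Compound 4 is `O=C(/C(=C\c1ccc(Br)cc1)S(=O)(=O)Cc1ccc(F)cc1)c1ccc(Br)cc1`. It differs from compound 3 only at the sulfonyl sulfur: 4-fluorobenzyl in place of 2-bromophenyl on a sulfonyl sulfur. Within the data shown here, no measured pair isolates this exchange, so the step from compound 1 to compound 2 does not bear on it directly. Compound 1 already carries the 4-fluorobenzyl group and gives 10000 nM, but its other aryl differs from that of compound 4, so only the two values themselves can be compared. Given the 4-bromophenyl group shared with compound 3, no change beyond the scatter is expected in this assay, that is no change at the digits printed from compound 3 to compound 4 (within the scatter). Compound 4 is therefore estimated at 1000 nM, within 300 nM to 4000 nM.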

Compound 4, concentration for 50% growth inhibition: 25000 nM
Estimate against measurement, compound 4: 25-fold (1.40 log units) below; measured number outside the range, above it.
By their numbers in this assay, from the lowest: compounds 2 and 3 (each within the scatter of the next); then compound 1; then compound 4.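

In this assay, 4-fluorobenzyl in place of 2-bromophenyl on the sulfonyl sulfur gives a 25-fold higher number from compound 3 to compound 4 (1.40 log units; beyond the scatter) with nothing else changed. With 4-fluorobenzyl held fixed, the aryl group on the double-bonded chain carbon also matters, since 4-bromophenyl in place of 2,5-dimethylphenyl gives a 25-fold higher number from compound 2 to compound 4 (1.40 log units; beyond the scatter) and bromo in place of hydroxy on an aromatic carbon gives a 2.5-fold higher number from compound 1 to compound 4 (0.40 log units; beyond the scatter) as the smaller step. No measurement shown here explains these steps.

From the compounds shown here alone, whether 2-bromophenyl on the sulfonyl sulfur keeps its advantage over 4-fluorobenzyl when 2,5-dimethylphenyl or 4-hydroxyphenyl sits on the double-bonded chain carbon remains open. Also open, going by these compounds, is what a plain phenyl, an unsubstituted benzyl or an aminophenyl group would give on the sulfonyl sulfur.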